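The compounds below may be only part of what the source reports. "The series", "measured", "known", "first", "only" and "open" are said of these compounds alone.

In a functional assay on MDA-MB-231 cells (Homo sapiens) for antiproliferative activity, read by MTT assay, with a stated time of 72 h (a lower number here means a stronger inhibitor, a higher number a weaker inhibitor), compound 1 (`O=C(CCc1cccc2c1B(O)OC2)Nc1ccccc1`) gives 230 nM. Compound 2 (`O=C(CCc1cccc2c1B(O)OC2)Nc1nccs1`) gives only a limit, > 100000 nM, and not a number. Within the data shown here, the single measured step, an at least 430-fold higher number from compound 1 to compound 2 (2.63 log units; beyond the scatter), is large. Compound 3 (`O=C(CCc1cccc2c1B(O)OC2)Nc1ccc(Cl)cc1`) carries this change from compound 2: 4-chlorophenyl in place of 1,3-thiazol-2-yl on an amide-type nitrogen. In words, 4-chlorophenyl stands in place of 1,3-thiazol-2-yl on an amide-type nitrogen, which restores a six-membered aromatic ring of carbon only, as in compound 1. A large move to a lower number is therefore expected, roughly undoing an at least 430-fold higher number from compound 1 to compound 2 (2.63 log units; beyond the scatter), and the expected step is an at least 330-fold lower number from compound 2 to compound 3 (2.52 log units; beyond the scatter). The estimate for compound 3 is 300 nM, with an expected range of 60 nM to 2000 nM.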

Compound 3, half-maximal inhibitory concentration: 3600 nM
Compound 3: the middle estimate sits 12-fold (1.08 log units) below what was measured; the measured number lies above the stated range.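

Returning to a six-membered aromatic ring of carbon only on the amide-type nitrogen recovers much of what 1,3-thiazol-2-yl lost, with an at least 27-fold lower number from compound 2 to compound 3 (1.44 log units; beyond the scatter). Compound 2 itself gives only a limit and not a number: the limit of > 100000 nM in this assay, at which 1 of the 3 values shown sits. New here is that the ring type alone does not set the result, since chloro in place of hydrogen on that ring also matters, with a 16-fold higher number from compound 1 to compound 3 (1.19 log units; beyond the scatter). The compounds shown leave open whether a methoxy group or an amine in the place of chloro would shift the number as far.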